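Removing the benzoyl from compound 1: expected cytotoxicity

The source may report more compounds than this note shows. Statements on the series, on what has been measured and on what is new or still open speak of the compounds shown alone.

Compound 1 `CCOC(=O)CCCCCOc1cccc(CN(C(=O)c2ccccc2)C(C)C)c1` was tested in an ADME assay on BJ cells (Homo sapiens) for cytotoxicity, read by CellTiter-Glo and resazurin assay, with a stated time of 72 h; a lower number here means that less compound is needed, a higher number that more compound is needed for the effect. In this assay compound 1 reaches only the limit > 26000 nM, so no number is known for it. Compound 2 `CCOC(=O)CCCCCOc1cccc(CN(C(=O)c2ccc(-c3ccncc3)cc2)C(C)C)c1` likewise gives only the limit > 26000 nM in this assay. The step from compound 1 to compound 2, pyridin-4-yl in place of hydrogen on an aromatic carbon, is therefore a step that the two limits leave unreadable from compound 1 to compound 2; both readings sit at the limit of > 26000 nM in this assay, at which 2 of the 2 values shown sit.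

Compound 3 `CCOC(=O)CCCCCOc1cccc(CNC(C)C)c1` differs from compound 1 by hydrogen in place of benzoyl on an amine nitrogen. Going by the values given here, no measured step removes the benzoyl, and the one step that is available is unreadable, so this assay offers no direction for the change. Compound 3 is therefore expected to remain at or near the limit, with the step from compound 1 to compound 3 estimated as a step that the limit leaves unreadable from compound 1 to compound 3. The estimate for compound 3 in this assay is 30000 nM, within 12000 nM to 80000 nM.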

Compound 3, half-maximal effective concentration: > 26000 nM
Compound 3: no number, only a limit; the forecaster's own chance of this, stated with the estimate: 75%; the middle value is on the limit's open side.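

In this assay compound 3 gives only a limit, as compound 1 does, so the step between them cannot be read: the limit of > 26000 nM in this assay, at which 3 of the 3 values shown sit. The compounds shown leave open whether adding pyridin-4-yl or removing benzoyl changes the reading at all in this assay.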